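Cyclopropyl in place of a larger group on the shared core

The source may report more compounds than this note shows. Statements on the series, on what has been measured and on what is new or still open speak of the compounds shown alone.

Measured in a functional assay on HCT-116 cells (Homo sapiens) for antiproliferative activity, read by MTT assay, with a stated time of 72 h; a lower number here means a stronger inhibitor, a higher number a weaker inhibitor:
Compound 1 `O=C1O[C@H]([C@@H](O)Cn2cc(-c3ccc(Br)cc3)nn2)C(OCc2ccccc2)=C1OCc1ccccc1`: 9420 nM
Compound 2 `COc1ccccc1-c1cn(C[C@H](O)[C@H]2OC(=O)C(OCc3ccccc3)=C2OCc2ccccc2)nn1`: > 100000 nM, a limit
Compound 3 `O=C1O[C@H]([C@@H](O)Cn2cc(CNS(=O)(=O)c3ccc(F)cc3)nn2)C(OCc2ccccc2)=C1OCc1ccccc1`: 22900 nM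

Of the two actual numbers, compound 3 has the higher, with compound 1 the lower. Compound 2 gives only a limit. Compound 4 `O=C1O[C@H]([C@@H](O)Cn2cc(C3CC3)nn2)C(OCc2ccccc2)=C1OCc1ccccc1` carries cyclopropyl in place of (((4-fluorophenyl)sulfonyl)amino)methyl on an aromatic carbon. All measured steps change this same carbon: a 2.4-fold higher number from compound 1 to compound 3 (0.39 log units; beyond the scatter), an at least 10-fold higher number from compound 1 to compound 2 (1.02 log units; beyond the scatter) and an at least 4.3-fold lower number from compound 2 to compound 3 (0.64 log units; beyond the scatter). None of them introduces cyclopropyl, so the direction is uncertain, but a modest step toward a higher number is expected in this assay. The estimate amounts to an expected 2.2-fold higher number from compound 3 to compound 4 (0.34 log units; beyond the scatter). For compound 4 the estimated value is 50000 nM, with a range of 15000 nM to 100000 nM.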

Compound 4, half-maximal inhibitory concentration: 30400 nM
Beside the measured number, compound 4's estimate is 1.6-fold (0.22 log units) above it; low and high end bracket the measured number.
By their numbers in this assay, from the lowest: compound 1; then compounds 3 and 4 (each within the scatter of the next). At a limit, above all of these: compound 2.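

Replacing the (((4-fluorophenyl)sulfonyl)amino)methyl group with the much smaller cyclopropyl gives a 1.3-fold higher number from compound 3 to compound 4 (0.12 log units; within the scatter) on this aromatic carbon, so the two groups cannot be told apart here. Cyclopropyl does not match 4-bromophenyl, with a 3.2-fold higher number from compound 1 to compound 4 (0.51 log units; beyond the scatter) in that comparison, yet it surpasses 2-methoxyphenyl, with an at least 3.2-fold lower number from compound 2 to compound 4 (0.51 log units; beyond the scatter) as the step. That last step rests on a limit for compound 2, not a number: the limit of > 100000 nM in this assay, at which 1 of the 4 values shown sits. The compounds shown leave open how an amine or a carboxylic acid on this carbon would read, and whether an unsubstituted phenyl would match 4-bromophenyl.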